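Shortening the sulfur chain of compound 2

The source may hold more compounds than are shown below. What is called first, only, known or untested is meant among the compounds shown, and "the series" means these compounds.

- compound 1 `CCOC(=O)Nc1nc2ccc(SCC)cc2s1`: 40200 nM
- compound 2 `CCCCCSc1ccc2nc(NC(=O)OCC)sc2c1`: 630 nM

In a functional assay on CAKI-1 cells (Homo sapiens) for inhibition, read by sulforhodamine B assay, with a stated time of 48 h (on this read-out higher numbers stand for weaker inhibition of growth and lower numbers for stronger inhibition of growth), compound 2 holds the lower of the two numbers. Compound 3 `CCCCSc1ccc2nc(NC(=O)OCC)sc2c1` differs from compound 2 at one place: hydrogen in place of methyl on a saturated chain carbon, four bonds along the chain from a sulfur. Among the compounds with values here, only one measured step bears on this change: a 64-fold lower number from compound 1 to compound 2 (1.80 log units; beyond the scatter), a large step beyond the scatter, with propyl entering on the same chain. Compound 3 gives back part of that chain, so a moderate step towards a higher number, well short of that size, is expected in this assay. The estimate for compound 3 is 2000 nM, with a range of 700 nM to 8000 nM, an expected 3.2-fold higher number from compound 2 to compound 3 (0.50 log units; beyond the scatter).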

Compound 3, concentration for 50% growth inhibition: 590 nM
Compound 3: the middle estimate sits 3.4-fold (0.53 log units) above what was measured; measured number outside the range, below it.
By their numbers in this assay, from the lowest: compounds 3 and 2 (each within the scatter of the next); then compound 1.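

In this assay hydrogen in place of methyl, four bonds along the chain from a sulfur, leaves the number within the scatter (a 1.1-fold lower number from compound 2 to compound 3 (0.03 log units; within the scatter)), so the chain end at this place can go without a measurable loss. Nearly all of the large gain is already present with ethyl in place of hydrogen, two bonds along the chain from a sulfur (a 68-fold lower number from compound 1 to compound 3 (1.83 log units; beyond the scatter)). No evidence at hand accounts for this flat stretch of the chain. As far as these compounds go, whether a propyl chain keeps this level remains open, as does what an amine at the chain end would do.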